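The source may hold more compounds than are shown below. What is called first, only, known or untested is meant among the compounds shown, and "the series" means these compounds.

Compound 3 `CN(C)c1cc2[nH]c(C3CCCCC3)nc2cc1NC(=O)c1cccs1` was tested in an ADME assay on Vero cells (Chlorocebus sabaeus) for cytotoxicity, read by resazurin assay, with a stated time of 3 days; on this read-out lower numbers stand for stronger inhibition and higher numbers for weaker inhibition. In this assay compound 3 gives > 100 ug/mL, which is a limit of the assay and not a number. Compound 1 `CN(C)c1cc2[nH]c(C3CCCCC3)nc2cc1NC(=O)c1ccc(OC(F)F)cc1` gives > 100 ug/mL in this assay, also a limit. Compound 2 `CCCOCC(=O)Nc1cc2nc(C3CCCCC3)[nH]c2cc1N(C)C` gives < 50 ug/mL in this assay, again a limit. Among the measured compounds shown here, two of the three values sit at the limit of > 100 ug/mL in this assay, at which 2 of the 3 values shown sit, and one at the limit of < 50 ug/mL in this assay, at which 1 of the 3 values shown sits, so compound 3 stands at the upper limit alongside compound 1, with compound 2 as the single value on the other side.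

Compound 4 `CN(C)c1cc2[nH]c(C3CCCCC3)nc2cc1NC(=O)c1cccc(Br)c1` differs from compound 3 in one place: 3-bromophenyl in place of thiophen-2-yl on a carbonyl carbon. The measured steps that bear on this exchange are a step that the two limits leave unreadable from compound 1 to compound 3 and an at least 2.0-fold higher number from compound 2 to compound 3 (0.30 log units; that floor lies within the scatter), while an at least 2.0-fold lower number from compound 1 to compound 2 (0.30 log units; that floor lies within the scatter) runs the other way. None of these yields a readable size beyond the scatter, and compound 1 and compound 3 both sit at the limit. For compound 4 in this assay a step that the limit leaves unreadable from compound 3 to compound 4 is therefore expected, meaning no change beyond the scatter. Compound 4 is estimated at 150 ug/mL, within 60 ug/mL to 400 ug/mL, most likely again reported only as a limit.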

Compound 4, half-maximal inhibitory concentration: > 100 ug/mL
Compound 4 ended at the assay's limit; the forecaster's own chance of this, stated with the estimate: 75%; the middle value does not contradict the limit.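

With 3-bromophenyl in place of thiophen-2-yl on the carbonyl carbon, compound 4 gives > 100 ug/mL in this assay, which is a limit and not a number. Compound 1, compound 3 and compound 4 carry three different aromatic groups at this place and all end at the same limit, while compound 2, with its propoxymethyl, goes against this pattern: the limit of > 100 ug/mL in this assay, at which 3 of the 4 values shown sit. Among the compounds shown here, the one readable step is an at least 2.0-fold higher number from compound 2 to compound 4 (0.30 log units; that floor lies within the scatter), and the steps among the compounds at the upper limit cannot be read.

From the compounds shown here alone, how far compound 1, compound 3 and compound 4 each lie past the limit remains open. Also open, going by these compounds, is whether a longer chain, or a group carrying an amine or a carboxylic acid, on this carbonyl carbon would give a value on the side of compound 2.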